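The source may report more compounds than this note shows. Statements on the series, on what has been measured and on what is new or still open speak of the compounds shown alone.

Compound 1 `CC(=O)OC(/C=C/c1ccccc1)=C1\C(=O)C=C(C)C1=O`: 5.5 ug/mL
Compound 2 `COC(/C=C/c1ccc(Cl)cc1)=C1\C(=O)C=C(C)C1=O`: 5.5 ug/mL
Compound 3 `COC(/C=C/c1cccs1)=C1\C(=O)C=C(C)C1=O`: 3 ug/mL

In an ADME assay on Vero cells (Chlorocebus sabaeus) for cytotoxicity, read by neutral red uptake (a lower number here means a stronger inhibitor, a higher number a weaker inhibitor), compound 3 gives 3 ug/mL, which lies within the usual scatter of both other compounds. Compound 4 `COC(/C=C/c1ccco1)=C1\C(=O)C=C(C)C1=O` carries furan-2-yl in place of thiophen-2-yl on a double-bonded chain carbon bound to a double-bonded chain carbon. Among the measured compounds shown here, no measured pair differs in one place only, so no direct precedent exists for this swap. The expectation rests on the close grouping of compound 1 at 5.5 ug/mL and compound 2 at 5.5 ug/mL around compound 3, and no step beyond the scatter is expected. The estimated step of a 1.2-fold higher number from compound 3 to compound 4 (0.07 log units; within the scatter) is accordingly small. For compound 4, the expected value is 3.5 ug/mL, with an estimated range of 1.8 ug/mL to 7 ug/mL.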

Compound 4, half-maximal inhibitory concentration: 3.3 ug/mL
For compound 4 the middle estimate is 1.1-fold (0.03 log units) above the measured one; measured number inside the range.
By their numbers in this assay, from the lowest: compounds 3, 4, 1 and 2 (each within the scatter of the next).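

In this assay, among the compounds shown here, the exchange of thiophen-2-yl for furan-2-yl on a double-bonded chain carbon bound to a double-bonded chain carbon gives a 1.1-fold higher number from compound 3 to compound 4 (0.04 log units; within the scatter) and is the only comparison here that differs in one place. At this position, replacing the ring sulfur with oxygen therefore leaves the read-out within the scatter. Nothing available here explains this result.

Whether the position accepts a group of another kind remains open, as no compound shown carries an amine or a carboxylic acid in place of the five-membered ring. Going by these compounds, how a longer chain would read there is equally open.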